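Cytotoxicity of three compounds and an expectation for compound 4

The compounds below may be only part of what the source reports. "The series", "measured", "known", "first", "only" and "open" are said of these compounds alone.

Compound 1, `CN(C(=O)c1ccccn1)c1ccc(C(O)(C(F)(F)F)C(F)(F)F)cc1`: in an ADME assay on Li23 cells (Homo sapiens) for cytotoxicity, read by WST assay (on this read-out higher numbers stand for lower toxicity in this test and lower numbers for higher toxicity in this test), compound 1 gives > 100000 nM, a limit of the assay rather than a number.
Compound 2, `CN(C(=O)c1ccsc1)c1ccc(C(O)(C(F)(F)F)C(F)(F)F)cc1`: compound 2 gives 44000 nM.
Compound 3, `Cc1ccccc1S(=O)(=O)N(C)c1ccc(C(O)(C(F)(F)F)C(F)(F)F)cc1`: compound 3 gives 12000 nM.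

Compound 3 holds the lowest of the two numbers; the value of compound 2 stands higher. The only measured step, an at least 2.2-fold lower number from compound 1 to compound 2 (0.35 log units; beyond the scatter), starts from a limit, as shown by the limit of > 100000 nM in this assay, at which 1 of the 3 values shown sits, and is an amide change. For the measured compounds named here, compound 4, `COc1ccc(S(=O)(=O)N(C)c2ccc(C(O)(C(F)(F)F)C(F)(F)F)cc2)cc1`, differs from compound 3 by 4-methoxyphenyl in place of 2-methylphenyl on a sulfonyl sulfur; no measured step touches this sulfonyl position, so no shift beyond the scatter is expected, a 1.3-fold higher number from compound 3 to compound 4 (0.10 log units; within the scatter). Compound 4 is therefore estimated at 15000 nM, within 6000 nM to 40000 nM.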

Compound 4, half-maximal cytotoxic concentration: 7900 nM
Beside the measured number, compound 4's estimate is 1.9-fold (0.28 log units) above it, and the stated range covers the measured number.
By their numbers in this assay, from the lowest: compounds 4 and 3 (each within the scatter of the next); then compound 2. At a limit, above all of these: compound 1.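

For the compounds shown here, this is the first measured step at the sulfonyl position: in this assay, 4-methoxyphenyl in place of 2-methylphenyl on a sulfonyl sulfur gives a step within the scatter (a 1.5-fold lower number from compound 3 to compound 4 (0.18 log units; within the scatter)). This change, which brings in a hydrogen-bond acceptor, therefore does not separate compound 3 from compound 4 in this test. Nothing shown here offers a reason for this result.

The compounds shown leave open whether a group carrying an amine or a carboxylic acid on the sulfonyl sulfur would move the number beyond the scatter. As far as these compounds go, a longer alkyl chain in that place is equally open.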